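The source may report more compounds than this note shows. Statements on the series, on what has been measured and on what is new or still open speak of the compounds shown alone.

Working notes on the series. Compound 1 `CS(=O)(=O)c1ccc(C(=O)N2CCC(C(=O)N(Cc3ccccc3)c3ccccc3)CC2)cc1[N+](=O)[O-]` in an assay on isolated protein for inhibition of thyroid hormone receptor beta (Homo sapiens), read by fluorescence polarization (a lower number here means a stronger inhibitor, a higher number a weaker inhibitor), gives > 60000 nM, which is a limit of the assay and not a number. Compound 2 `CN(Cc1ccccc1)C(=O)C1CCN(C(=O)c2ccc(S(C)(=O)=O)c([N+](=O)[O-])c2)CC1` in this assay gives > 60000 nM, again a limit rather than a number. Going by the values given here, the only measured step, methyl in place of phenyl on an amide-type nitrogen, is a step that the two limits leave unreadable from compound 1 to compound 2. Compound 2 thus stands only at a limit in this assay, and the limit of > 60000 nM in this assay, at which 2 of the 2 values shown sit, sums up everything the two measured values show. Compound 3 `CC(C)N(C(=O)C1CCN(C(=O)c2ccc(S(C)(=O)=O)c([N+](=O)[O-])c2)CC1)C(C)C` carries diisopropylamino in place of benzyl(methyl)amino on a carbonyl carbon. Among the compounds with values here, the single measured step bears on this change only in that neither of its ends produced a number, so no size in either direction can be read from it. The expected step is a step that the limit leaves unreadable from compound 2 to compound 3, that is, none beyond the scatter as far as the data can say. Compound 3 is expected to give about 80000 nM in this assay, with a range from 20000 nM to 300000 nM, most probably reported once more as a limit.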

Compound 3, half-maximal inhibitory concentration: > 60000 nM
Compound 3: no number, only a limit; the forecaster's own chance of this, stated with the estimate: 85%; the middle value lies beyond the limit too.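

Going by these compounds alone, compound 2 and compound 3 both rest at a limit in this assay, so no step between them can be read. The compounds shown leave open whether any change on the shared core gives a readable number, and the picture so far is a single limit: the limit of > 60000 nM in this assay, at which 3 of the 3 values shown sit.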